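Adding a Sulfamoyl Group: Expected Cytotoxicity of Compound 4

This account rests on a few compounds, and the source may have more. Where it says the series, first, only, none or still open, it means among the compounds named here.

Of the compounds shown here, three have been measured in a functional assay on cells (Cancer cell lines, Homo sapiens) for cytotoxicity, read by sulforhodamine B assay, with a stated time of 48 h; on this read-out higher numbers stand for weaker inhibition of growth and lower numbers for stronger inhibition of growth. Compound 2 `Oc1ccc(O)c(-c2cc(-c3ccccc3)nn2-c2ccccc2)c1` gives 22600 nM, the highest of the three numbers. Compound 1 `COc1ccc(OC)c(-c2cc(-c3ccccc3)nn2-c2ccc(S(N)(=O)=O)cc2)c1` gives 13000 nM, within the scatter of compound 2. Among the measured compounds shown here, compound 3 `Oc1ccc(O)c(-c2cc(-c3ccc(Cl)cc3)nn2-c2ccccc2)c1` gives 8860 nM, and the step of a 2.6-fold lower number from compound 2 to compound 3 (0.41 log units; beyond the scatter) is the only measured single change, a chloro in place of hydrogen on an aromatic carbon. Compound 4 `NS(=O)(=O)c1ccc(-n2nc(-c3ccccc3)cc2-c2cc(O)ccc2O)cc1` differs from compound 2 by sulfamoyl in place of hydrogen on an aromatic carbon. For the measured compounds named here, no measured step covers this change; compound 1 carries the same group among other changes and sits within the scatter of compound 2. Compound 4 is therefore expected to show no step beyond the scatter in this assay, the estimated step being a 1.4-fold lower number from compound 2 to compound 4 (0.15 log units; within the scatter). Compound 4 is estimated at 16000 nM, with a range from 6000 nM to 40000 nM.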

Compound 4, concentration for 50% growth inhibition: 88100 nM
Beside the measured number, compound 4's estimate is 5.5-fold (0.74 log units) below it; the measured number lies above the stated range.
By their numbers in this assay, from the lowest: compounds 3, 1 and 2 (each within the scatter of the next, the first and the last beyond it); then compound 4.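

In this assay, sulfamoyl on an aromatic carbon, para to a large group, now has a step of its own (a 3.9-fold higher number from compound 2 to compound 4 (0.59 log units; beyond the scatter)), and it moves the number towards weaker inhibition of growth. With sulfamoyl held in place, 2,5-dihydroxyphenyl in place of 2,5-dimethoxyphenyl also gives a step beyond the scatter (a 6.8-fold higher number from compound 1 to compound 4 (0.83 log units; beyond the scatter)), so the outcome with sulfamoyl present differs with the group carried alongside it. Nothing available here explains either step. The compounds shown leave open whether an amine or a carboxylic acid at this position would move the number the same way. They also leave open what sulfamoyl does to a compound carrying 2,5-dimethoxyphenyl, as no partner without sulfamoyl is shown for compound 1.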